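Triazole substituent swap on a shared lactone core

The source may hold more compounds than are shown below. What is called first, only, known or untested is meant among the compounds shown, and "the series" means these compounds.

Measured so far:
Compound 1 `O=C1O[C@H]([C@@H](O)Cn2cc(-c3cccc(O)c3)nn2)C(OCc2ccccc2)=C1OCc1ccccc1` gave 54100 nM
Compound 2 `O=C1O[C@H]([C@@H](O)Cn2cc(CCCCl)nn2)C(OCc2ccccc2)=C1OCc1ccccc1` gave 58800 nM

Compound 1 `O=C1O[C@H]([C@@H](O)Cn2cc(-c3cccc(O)c3)nn2)C(OCc2ccccc2)=C1OCc1ccccc1` was tested in a functional assay on CFPAC-1 cells (Homo sapiens) for antiproliferative activity, read by MTT assay, with a stated time of 72 h (a higher number here means a weaker inhibitor, a lower number a stronger inhibitor), and compound 1 gave 54100 nM. Compound 2 `O=C1O[C@H]([C@@H](O)Cn2cc(CCCCl)nn2)C(OCc2ccccc2)=C1OCc1ccccc1` has 3-chloropropyl in place of 3-hydroxyphenyl on an aromatic carbon, and in this assay compound 2 gave 58800 nM. Compound 2 stands with the higher of the two numbers, but the step of a 1.1-fold higher number from compound 1 to compound 2 (0.04 log units; within the scatter) lies within the scatter, so the two cannot be ordered.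

Compound 3 `COc1ccc(-c2cn(C[C@H](O)[C@H]3OC(=O)C(OCc4ccccc4)=C3OCc3ccccc3)nn2)cc1` is not yet measured. Its difference from compound 2 is 4-methoxyphenyl in place of 3-chloropropyl on an aromatic carbon. Among the measured compounds shown here, the only step that bears on it, a 1.1-fold higher number from compound 1 to compound 2 (0.04 log units; within the scatter), exchanged an aryl group for the same 3-chloropropyl chain without a change beyond the scatter; returning an aryl group is therefore expected to give no step beyond the scatter in this assay, with a 1.1-fold lower number from compound 2 to compound 3 (0.05 log units; within the scatter). Compound 3 is estimated at 52000 nM, with a range of 20000 nM to 130000 nM.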

Compound 3, half-maximal inhibitory concentration: 26000 nM
Beside the measured number, compound 3's estimate is 2.0-fold (0.30 log units) above it, within the range that was stated.
By their numbers in this assay, from the lowest: compound 3; then compounds 1 and 2 (each within the scatter of the next).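

In this assay, the group on this aromatic carbon of the five-membered ring now makes a difference beyond the scatter, which the earlier pair did not show: 4-methoxyphenyl in place of 3-chloropropyl gives a 2.3-fold lower number from compound 2 to compound 3 (0.35 log units; beyond the scatter), and 4-methoxyphenyl in place of 3-hydroxyphenyl gives a 2.1-fold lower number from compound 1 to compound 3 (0.32 log units; beyond the scatter). Both steps are modest, and having an aryl group here is not enough in itself, as compound 1, with 3-hydroxyphenyl, stays within the scatter of compound 2, with its chain, while compound 3 does not. No supporting measurement is available to account for this difference.

As far as these compounds go, it remains open whether the methoxy group itself carries the step, which a plain phenyl group could help to settle. Also open, from the compounds shown here alone, is how an amine or a carboxylic acid on the phenyl ring would read in this assay.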